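Notes on the series: from compound 2 to compound 4

The source may report more compounds than this note shows. Statements on the series, on what has been measured and on what is new or still open speak of the compounds shown alone.

Cytotoxicity in a functional assay on SK-OV-3 cells (Homo sapiens) for cytotoxicity, read by MTT assay, with a stated time of 3 days (on this read-out higher numbers stand for weaker inhibition and lower numbers for stronger inhibition), for the three measured compounds:
compound 1 `N#Cc1c(Cl)nc(SCc2nc3ccccc3[nH]2)nc1-c1ccccc1` gives 3.37 nM
compound 2 `N#Cc1c(NN)nc(SCc2nc3ccccc3[nH]2)nc1-c1ccccc1` gives 2.7 nM
compound 3 `N#Cc1c(Nc2ccccc2)nc(SCc2nc3ccccc3[nH]2)nc1-c1ccccc1` gives 4.46 nM

Compound 2 stands at the low end of the three numbers, but nothing separates it from the others: a 1.2-fold lower number from compound 1 to compound 2 (0.10 log units; within the scatter) and a 1.7-fold higher number from compound 2 to compound 3 (0.22 log units; within the scatter) both fall within the scatter, as does a 1.3-fold higher number from compound 1 to compound 3 (0.12 log units; within the scatter). On the numbers shown, chloro, aminoamino and anilino on this aromatic carbon give indistinguishable read-outs in this assay.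

Compound 4 `N#Cc1c(NC(N)=O)nc(SCc2nc3ccccc3[nH]2)nc1-c1ccccc1` differs from compound 2 in one place: carbamoyl in place of amino on a nitrogen on an aromatic ring

Among the measured compounds shown here, two measured steps bear on this. The nearest analogy is the change on the same nitrogen, a 1.7-fold higher number from compound 2 to compound 3 (0.22 log units; within the scatter), where a far larger group entered without moving the number beyond the scatter. The step into compound 2 itself, a 1.2-fold lower number from compound 1 to compound 2 (0.10 log units; within the scatter), was likewise flat. Neither suggests that adding a carbamoyl on this nitrogen should alter the read-out in this assay; the expected step is therefore a 1.2-fold higher number from compound 2 to compound 4 (0.07 log units; within the scatter), no move beyond the scatter in either direction.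

Compound 4 is accordingly estimated at 3.2 nM in this assay, with a range of 1.2 nM to 8.5 nM.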

Compound 4, half-maximal inhibitory concentration: 6.75 nM
Estimate against measurement, compound 4: 2.1-fold (0.32 log units) below; measured number inside the range.
By their numbers in this assay, from the lowest: compounds 2, 1, 3 and 4 (each within the scatter of the next, the first and the last beyond it).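

Among the compounds shown here, at this position, a nitrogen on an aromatic ring, the change from amino to carbamoyl gives the first step in this assay that lies beyond the scatter (a 2.5-fold higher number from compound 2 to compound 4 (0.40 log units; beyond the scatter)), so a group on this nitrogen is not always without consequence for the read-out, although the step is modest. The separation holds only against compound 2, and the other two comparisons stay within the scatter (a 1.5-fold higher number from compound 3 to compound 4 (0.18 log units; within the scatter); a 2.0-fold higher number from compound 1 to compound 4 (0.30 log units; within the scatter)), so carbamoyl cannot be told from phenyl on this nitrogen, nor ureido from chloro on the aromatic carbon. No measurement at hand speaks to what lies behind the step from amino to carbamoyl.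

Open, as far as these compounds go, is whether acetyl on the same nitrogen, which keeps the carbonyl and lacks the amino of carbamoyl, would read with compound 2 or with compound 4, and whether methyl or a longer chain there would do either. Also open, from the compounds shown here alone, is whether the step recurs with other groups on the shared core, such as a carboxylic acid in place of the nitrile.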